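Replacing Methoxy with Dimethylamino in Compound 1

A few compounds are considered here, and "the series" means these few. Any claim that something is new, unique, unknown or untested is made for them only; others in the source may bear on it.

In a functional assay on HepG2 cells (Homo sapiens) for inhibition, read by MTT assay, with a stated time of 48 h (on this read-out lower numbers stand for stronger inhibition and higher numbers for weaker inhibition), compound 1 `COc1ccc(-n2c(S)nnc2-c2cc(OC)c(OC)c(OC)c2)cc1` gives 57500 nM. Compound 2 `COc1ccc(-n2c(SCC(=O)c3ccccc3)nnc2-c2cc(OC)c(OC)c(OC)c2)cc1`, with benzoylmethyl in place of hydrogen on a sulfur, gives 16200 nM. Compound 1 therefore stands highest of the two numbers and is the weaker of the pair. Going by the values given here, the only measured step, a 3.5-fold lower number from compound 1 to compound 2 (0.55 log units; beyond the scatter), is modest but beyond the scatter.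

Compound 3 `COc1cc(-c2nnc(S)n2-c2ccc(N(C)C)cc2)cc(OC)c1OC` keeps the hydrogen on sulfur and changes another part of compound 1: dimethylamino in place of methoxy on an aromatic carbon. Dimethylamino stands in place of methoxy on an aromatic carbon, turning 4-methoxyphenyl into 4-(dimethylamino)phenyl.

The measured step was made at the sulfur, so it bears on this change only as a rough guide to scale. Among the compounds with values here, no measured pair shows an exchange at the aromatic carbon, and the data give no direction for one. In this assay, no step beyond the scatter is therefore expected, and the estimated step is a 1.2-fold lower number from compound 1 to compound 3 (0.06 log units; within the scatter). For compound 3, the expected value is 50000 nM, with an estimated range of 17000 nM to 130000 nM.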

Compound 3, half-maximal inhibitory concentration: > 60000 nM
Compound 3 gave a limit, no number; the forecaster's own chance of this, stated with the estimate: 15%; middle value at least 1.2-fold (0.07 log units) from the limit.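

In this assay compound 3 gives no number but a limit of the assay: the limit of > 60000 nM in this assay, at which 1 of the 3 values shown sits.

Going by these compounds alone, this is the first reading at this place, on an aromatic carbon para to a large group, and the exchange of methoxy for dimethylamino reads as an at least 1.0-fold higher number from compound 1 to compound 3 (0.01 log units; that floor lies within the scatter). With the hydrogen kept on the sulfur, this change therefore shows no stronger inhibition than compound 1, which is something the earlier pair, changed only at the sulfur, could not show. The floor of the step does not separate compound 3 from compound 1, however, so the data show neither that dimethylamino weakens inhibition nor how large its true step may be.

The compounds shown leave open whether dimethylamino would act in the same way with benzoylmethyl on the sulfur, as in compound 2, since the one step at this place was read with the hydrogen on the sulfur. They also leave open how other groups would behave at this carbon, such as a primary amine, a carboxylic acid, a chlorine atom or a longer alkoxy chain.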